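Removing a methyl from compound 1

A few compounds are considered here, and "the series" means these few. Any claim that something is new, unique, unknown or untested is made for them only; others in the source may bear on it.

Compound 1 `Cc1ccccc1C(=O)Nc1ccc(-c2nnc(SC(C)C(=O)O)n2C)cc1` stands only at the limit of > 20000 nM in this assay, at which 1 of the 2 values shown sits: in an assay on 3T3-L1 cells for inhibition of diacylglycerol O-acyltransferase 1 (Mus musculus) (on this read-out higher numbers stand for weaker inhibition and lower numbers for stronger inhibition), compound 1 gives > 20000 nM, which is a limit of the assay and not a number. Compound 2 `Cn1c(OCC(C)(C)C(N)=O)nnc1-c1ccc(NC(=O)c2ccc3ccccc3c2)cc1` is the other measured compound, and in this assay compound 2 gives 6100 nM. Compound 3 `CC(Sc1nnc(-c2ccc(NC(=O)c3ccccc3)cc2)n1C)C(=O)O` differs from compound 1 by hydrogen in place of methyl on an aromatic carbon. Among the measured compounds shown here, no measured step covers this change, so no size or direction is known; the step expected is a number no higher from compound 1 to compound 3 (the limit leaves the size open), none beyond the scatter. Compound 3 is estimated at 20000 nM, between 5000 nM and 80000 nM, quite possibly reported only as a limit again.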

Compound 3, half-maximal inhibitory concentration: > 20000 nM
Compound 3 ended at the assay's limit (the forecaster's own chance of this, stated with the estimate: 60%); the middle value sits exactly at the limit.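

No step can be read from compound 1 to compound 3, since both compounds stand at the same limit, which is not a number: the limit of > 20000 nM in this assay, at which 2 of the 3 values shown sit.

The compounds shown leave open whether hydrogen in place of methyl changes inhibition at all.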